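A few compounds are considered here, and "the series" means these few. Any claim that something is new, unique, unknown or untested is made for them only; others in the source may bear on it.

Measured in a functional assay on NCI-H2122 cells (Homo sapiens) for inhibition, read by microscopy, with a stated time of 10 days; on this read-out lower numbers stand for stronger inhibition and higher numbers for weaker inhibition:

Compound 1 `Cc1nn(C)c2c1C(c1cc(F)cc(F)c1)C(C#N)=C(N)O2` gives 4200 nM.
Compound 2 `Cn1nc(-c2ccccc2)c2c1OC(N)=C(C#N)C2c1cc(F)cc(F)c1` gives 6600 nM.
Compound 3 `Cc1nn(C)c2c1C(c1ccc(C(F)(F)F)cc1)C(C#N)=C(N)O2` gives 2200 nM.

Compound 1 and compound 2 differ in a single place: phenyl in place of methyl on an aromatic carbon. In this assay that exchange made a 1.6-fold higher number from compound 1 to compound 2 (0.20 log units; within the scatter), so the two compounds cannot be told apart on this read-out. Compound 3 carries a different aryl group on the shared core than compound 1; the difference between these two cores is not broken down here. Its value and that of compound 1 lie within the scatter of each other, while the gap to compound 2 lies beyond it.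

Compound 4 `Cn1nc(-c2ccccc2)c2c1OC(N)=C(C#N)C2c1ccc(C(F)(F)F)cc1` has not yet been measured. Among the compounds with values here, it differs from compound 3 by phenyl in place of methyl on an aromatic carbon, the same change, at the same surroundings, as the one from compound 1 to compound 2. The step from compound 3 to compound 4 is therefore expected to be of similar size, a 1.6-fold higher number from compound 3 to compound 4 (0.20 log units; within the scatter), because the earlier pair showed a 1.6-fold higher number from compound 1 to compound 2 (0.20 log units; within the scatter). Compound 4 is estimated at 3500 nM, most likely between 1500 nM and 8000 nM.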

Compound 4, half-maximal inhibitory concentration: 4100 nM
Compound 4: the middle estimate sits 1.2-fold (0.07 log units) below what was measured; measured number inside the range.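

In this assay, placing phenyl instead of methyl on the aromatic carbon of the core with the trifluoromethyl-bearing aryl group gives a 1.9-fold higher number from compound 3 to compound 4 (0.27 log units; within the scatter), so the two compounds cannot be told apart on this read-out. Within the data shown here, this does not show that phenyl and methyl are equivalent in general, and it gives no firm size for the step, since only two cores are compared and each step is small enough to be ordinary scatter. What it does show is that, for these two cores, the exchange carries over with no detectable difference between them: the same change on two cores in this assay, a 1.6-fold higher number (0.20 log units; within the scatter) from compound 1 to compound 2 and a 1.9-fold higher number (0.27 log units; within the scatter) from compound 3 to compound 4, 1.2-fold (0.07 log units) apart, within the scatter of two such steps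

Only methyl and phenyl appear on this aromatic carbon, so the compounds shown leave open whether a group of another kind, such as an amine, a carboxylic acid or a longer chain, would move the number beyond the scatter. They also leave open whether the same exchange would behave alike on a core with a different aryl group.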